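This account rests on a few compounds, and the source may have more. Where it says the series, first, only, none or still open, it means among the compounds named here.

Measured in a functional assay on PA-1 cells (Homo sapiens) for antiproliferative activity, read by MTT assay, with a stated time of 48 h; on this read-out lower numbers stand for stronger inhibition and higher numbers for weaker inhibition:
- compound 1 `O=C1N(Cc2ccc(Br)cc2)c2ccc(Cl)cc2C1(O)Cc1nnn[nH]1` gives 35800 nM
- compound 2 `CN1C(=O)C(O)(Cc2nnn[nH]2)c2cc(Br)ccc21` gives > 100000 nM

For compound 2 the value > 100000 nM is a limit of this assay and not a number. Compound 3 `O=C1N(Cc2ccc(Br)cc2)c2ccc(Br)cc2C1(O)Cc1nnn[nH]1` departs from compound 2 by one change, methyl to 4-bromobenzyl: 4-bromophenyl in place of hydrogen on a saturated chain carbon bound to an amide-type nitrogen in a ring. Compound 1 also carries 4-bromobenzyl and gives 35800 nM. On that value, a clear step toward stronger inhibition is expected in this assay: an at least 3.3-fold lower number from compound 2 to compound 3 (0.52 log units; beyond the scatter). For compound 3 the estimated value is 30000 nM, with an expected range of 12000 nM to 80000 nM.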

Compound 3, half-maximal inhibitory concentration: > 100000 nM
Compound 3 was reported as a limit; the forecaster's own chance of this, stated with the estimate: 15%; at least 3.3-fold (0.52 log units) between middle value and limit.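

In this assay compound 3 gives > 100000 nM, which is a limit and not a number. With 4-bromobenzyl held fixed, bromo in place of chloro on an aromatic carbon gives an at least 2.7-fold higher number from compound 1 to compound 3 (0.44 log units; beyond the scatter), so 4-bromobenzyl alone does not secure the measurable value of compound 1. The change from methyl to 4-bromobenzyl cannot be read, because both ends of that step sit at a limit: the limit of > 100000 nM in this assay, at which 2 of the 3 values shown sit.

From the compounds shown here alone, whether 4-bromobenzyl improves on methyl with chloro in place stays open. Also open, going by these compounds, is how fluoro or methoxy would read on that aromatic carbon.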